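The compounds below may be only part of what the source reports. "The series", "measured", "known", "first", "only" and "open" are said of these compounds alone.

Measured so far:
- Compound 1 `COc1ccc(/C=C\c2cc(OC)c(OC)c(OC)c2)cc1OCc1ccccc1`: 39000 nM
- Compound 2 `COc1ccc(/C=C/CCCOc2cc(/C=C\c3cc(OC)c(OC)c(OC)c3)ccc2OC)cc1`: 47000 nM

In a functional assay on HT-29 cells (Homo sapiens) for inhibition, read by MTT assay, with a stated time of 3 days (on this read-out higher numbers stand for weaker inhibition and lower numbers for stronger inhibition), compound 1 stands at the lowest of the two numbers, and its nearest neighbour is compound 2, reached by a 1.2-fold higher number from compound 1 to compound 2 (0.08 log units; within the scatter), which lies within the scatter. Compound 3 `COc1ccc(/C=C\c2cc(OC)c(OC)c(OC)c2)cc1OCCC/C=C/c1ccc(Cl)cc1` differs from compound 1 by 4-(4-chlorophenyl)but-3-en-1-yl in place of phenyl on a saturated chain carbon bound to an oxygen on an aromatic ring. For the measured compounds named here, the one measured step that bears on this is the similar swap of 4-(4-methoxyphenyl)but-3-en-1-yl for phenyl at the same place, giving a 1.2-fold higher number from compound 1 to compound 2 (0.08 log units; within the scatter). No step beyond the scatter is therefore expected in this assay. Compound 3 is estimated at 45000 nM, between 20000 nM and 100000 nM, meaning an expected 1.2-fold higher number from compound 1 to compound 3 (0.06 log units; within the scatter).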

Compound 3, half-maximal inhibitory concentration: 18000 nM
Compound 3: middle estimate off by 2.5-fold (0.40 log units), on the high side; measured number outside the range, below it.
By their numbers in this assay, from the lowest: compound 3; then compounds 1 and 2 (each within the scatter of the next).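

In this assay, the group on this saturated chain carbon now makes a measurable difference: 4-(4-chlorophenyl)but-3-en-1-yl in place of phenyl gives a 2.2-fold lower number from compound 1 to compound 3 (0.34 log units; beyond the scatter) and so moves beyond the scatter. The end of the longer chain also matters, since chloro in place of methoxy on an aromatic carbon gives a 2.6-fold lower number from compound 2 to compound 3 (0.42 log units; beyond the scatter) and is a modest step. No measurement shown gives a reason for either step. As far as these compounds go, it remains open how a bromo, a nitrile or an amine in place of the chloro would read. From the compounds shown here alone, whether the same chain ending in an unsubstituted phenyl would differ from compound 1 also remains open.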